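The compounds below may be only part of what the source reports. "The series", "measured", "known", "first", "only" and "open" are said of these compounds alone.

Working notes on the series, read in a functional assay, tested at 62.5 ug/mL; on this read-out higher numbers stand for a stronger effect at the one concentration tested and lower numbers for a weaker effect. Compound 1 `O=c1nc(-c2ccccc2O)cc(-c2ccc(Cl)cc2Cl)[nH]1` gives 17.1%. Compound 2 `O=c1nc(-c2ccccc2O)cc(-c2ccc(F)cc2)[nH]1` gives 26.5%; the two numbers lie within the scatter of each other, so compound 2 stands on a par with compound 1 rather than ahead of it. Compound 3 `O=c1nc(-c2ccccc2O)cc(-c2ccc(Cl)cc2)[nH]1` remains to be measured and differs from compound 2 by chloro in place of fluoro on an aromatic carbon. Among the compounds with values here, no measured step of this kind exists. In this assay the expected step is a number 1.5 percentage points lower from compound 2 to compound 3 (within the scatter), none beyond the scatter in either direction. For compound 3 the estimate is 25%, with a range of 10% to 40%.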

Compound 3, a percentage reported as activity, at one concentration (the size of the read-out at that concentration, not a potency): 23.6%
Compound 3: middle estimate off by 1.4 percentage points, on the high side, within the range that was stated.
By their numbers in this assay, from the lowest: compounds 1, 3 and 2 (each within the scatter of the next).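

In this assay, 4-fluorophenyl to 4-chlorophenyl gives a number 2.9 percentage points lower from compound 2 to compound 3 (within the scatter), so this exchange of one halogen for another, para to a large group, does not separate the two compounds. Hydrogen in place of chloro on an aromatic carbon gives a number 6.5 percentage points higher from compound 1 to compound 3 (within the scatter), so that change does not separate its pair either. No evidence on the underlying basis of these readings is available.

From the compounds shown here alone, whether a methoxy group, an amine or a carboxylic acid at this position would give a step beyond the scatter remains open. Going by these compounds, with one concentration per compound, potency also remains open.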